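Swapping isopropyl for methyl at the end of the chain

The compounds below may be only part of what the source reports. "The series", "measured", "known", "first", "only" and "open" are said of these compounds alone.

Three compounds share one core and differ only in the aromatic group at the far end. Compound 1 `CC#CC(CC(=O)O)c1ccc(OCc2ccn3cc(-c4ccc(F)cc4)nc3c2)cc1` carries a 4-fluorophenyl; in an assay on isolated protein for agonist activity at Free fatty acid receptor 1 (Homo sapiens) (a higher number here means that more compound is needed for the effect, a lower number that less compound is needed), compound 1 gives 783 nM. Compound 2 `CC#CC(CC(=O)O)c1ccc(OCc2ccn3cc(-c4cccc(C)c4)nc3c2)cc1` carries a 3-methylphenyl, and in this assay compound 2 gives 1510 nM. Compound 3 `CC#CC(CC(=O)O)c1ccc(OCc2ccn3cc(-c4ccc(C(C)C)cc4)nc3c2)cc1` carries a 4-isopropylphenyl, and in this assay compound 3 gives 615 nM, the smallest of the three numbers, though the step of a 1.3-fold lower number from compound 1 to compound 3 (0.10 log units; within the scatter) shows that compound 1 is not separated from it, while a 2.5-fold lower number from compound 2 to compound 3 (0.39 log units; beyond the scatter) is.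

Compound 4 `CC#CC(CC(=O)O)c1ccc(OCc2ccn3cc(-c4ccc(C)cc4)nc3c2)cc1` is not yet measured. Its change from compound 3 is methyl in place of isopropyl on an aromatic carbon. The step that bears on it most directly is a 1.3-fold lower number from compound 1 to compound 3 (0.10 log units; within the scatter), which replaced a small group with isopropyl at the same place and moved the number only within the scatter. A methyl is between those two in size, so in this assay compound 4 is expected to land close to compound 3, with a 1.2-fold higher number from compound 3 to compound 4 (0.09 log units; within the scatter) expected to stay within the scatter. The estimate for compound 4 in this assay is 750 nM, between 400 nM and 1500 nM.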

Compound 4, half-maximal effective concentration: 618 nM
Estimate against measurement, compound 4: 1.2-fold (0.08 log units) above; the range from low to high includes it.
By their numbers in this assay, from the lowest: compounds 3, 4, 1 and 2 (each within the scatter of the next, the first and the last beyond it).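

With a 1.0-fold higher number from compound 3 to compound 4 (0.00 log units; within the scatter) in this assay, shortening isopropyl to methyl at this aromatic carbon, para to a large group, leaves the number unchanged within the scatter. Methyl also matches fluoro, with a 1.3-fold lower number from compound 1 to compound 4 (0.10 log units; within the scatter) at the same carbon, so fluoro, methyl and isopropyl cannot be told apart here, while moving the methyl does register: a 2.4-fold lower number from compound 2 to compound 4 (0.39 log units; beyond the scatter) is a modest step beyond the scatter for 4-methylphenyl in place of 3-methylphenyl. No measurement is available to explain why the place of the methyl registers when the choice among these three groups does not.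

Going by these compounds, whether this tolerance extends to an amine, a carboxylic acid or a longer chain at this carbon stays open. All three groups compared here at this carbon are small and uncharged, so the pattern covers only compounds 1, 3 and 4.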